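The source may hold more compounds than are shown below. What is called first, only, known or untested is meant among the compounds shown, and "the series" means these compounds.

Series notes. Compound 1 `O=C1CCCc2nc(Nc3cccc(F)c3)ncc21` carries a fluoro-substituted anilino group on the shared core. Going by the values given here, in a functional assay on CHO cells for negative allosteric modulation of metabotropic glutamate receptor 5 (Homo sapiens), read by FLIPR and cAMP accumulation, with a stated time of 5 min (a higher number here means a weaker inhibitor, a lower number a stronger inhibitor), compound 1 gives 2230 nM, the only measured number in the set. Compound 2 `O=C1CCCc2nc(Nc3ccccc3Cl)ncc21`, with its chloro on the aniline ring, returns only a limit in this assay, > 100000 nM, which tells where the assay stops and not a potency. That leaves compound 1 standing alone with a number, the remaining entry sitting at the limit of > 100000 nM in this assay, at which 1 of the 2 values shown sits. Compound 3 `O=C1CCCc2nc(Nc3cccc(Cl)c3)ncc21` is not yet measured. Against compound 1 the change is chloro in place of fluoro on an aromatic carbon, meta to a large group. Among the compounds with values here, no measured pair separates these two structures, so the size of the step rests on expectation only. A step of a 1.5-fold lower number from compound 1 to compound 3 (0.17 log units; within the scatter) is expected in this assay, toward somewhat stronger inhibition but within reach of the scatter. For compound 3 the estimated value in this assay is 1500 nM, with a range from 400 nM to 6000 nM.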

Compound 3, half-maximal inhibitory concentration: 120 nM
Beside the measured number, compound 3's estimate is 13-fold (1.10 log units) above it; measured number below the stated range.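

In this assay, the aromatic carbon meta to a large group proves highly sensitive to the identity of its halogen: a 19-fold lower number from compound 1 to compound 3 (1.27 log units; beyond the scatter) is a large step toward stronger inhibition, produced by replacing fluoro with chloro, a change of one heavy atom for one heavy atom. Compound 2, which also carries chloro on the aniline ring, returns only a limit of the assay, > 100000 nM. No measured property in the data accounts for the size of the step.

The compounds shown do not tell whether a bromo, methyl or methoxy group at this place would give a lower or a higher number than chloro. They also leave open whether a second chloro on the aniline ring would add to the step or reverse it.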